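The source may hold more compounds than are shown below. What is called first, only, known or untested is meant among the compounds shown, and "the series" means these compounds.

The account starts from compound 1 `COc1ccc(-c2cc(=O)c3c(OC)cc(OC)cc3[nH]2)cc1`. In a functional assay on KOPN-8 cells (Homo sapiens) for antiproliferative activity, with a stated time of 72 h (a lower number here means that less compound is needed, a higher number that more compound is needed for the effect), compound 1 gives only a limit, > 31100 nM, so no number places it among the measured compounds. A second measured compound, compound 2 `COc1ccc(-c2cc(=O)c3c(OC)cc(OC)cc3n2S(=O)(=O)c2cc(F)c(F)c(F)c2)cc1`, is also shown. In this assay compound 2 likewise gives only a limit, > 65500 nM. Both values shown are limits (the limit of > 31100 nM in this assay, at which 1 of the 2 values shown sits, (the limit of > 65500 nM in this assay, at which 1 of the 2 values shown sits)), so the gap between compound 1 and compound 2 cannot be sized. Compound 3 `COc1ccc(-c2cc(=O)c3c(OC)cc(OC)cc3n2S(=O)(=O)c2ccc(Br)s2)cc1` is the member not yet measured; the change from compound 1 is (5-bromothiophen-2-yl)sulfonyl in place of hydrogen on an aromatic nitrogen. Since neither measured compound yields a number, the step in this assay from compound 1 to compound 3 is expected to be none beyond the scatter, in the sense that compound 3 is expected to remain at a limit. Compound 3 is therefore estimated at 60000 nM, with a range from 20000 nM to 200000 nM. The step this estimate implies, a step that the limit leaves unreadable from compound 1 to compound 3, is expected to stay within the scatter.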

Compound 3, half-maximal effective concentration: > 48200 nM
Compound 3 ended at the assay's limit (the forecaster's own chance of this, stated with the estimate: 85%); the middle value is on the limit's open side.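

In this assay compound 3 gives > 48200 nM, which is a limit. For the compounds shown here, all three values are limits, so no step to compound 3 can be read from compound 1 or compound 2. The compounds shown leave open whether either sulfonyl group changes the antiproliferative effect on these cells, and whether the two sulfonyl groups differ.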